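The compounds below may be only part of what the source reports. "The series", "measured", "known", "first", "only" and "open" are said of these compounds alone.

Compound 1 `O=C(NO)c1ccc(N(Cc2ccc(C(F)(F)F)cc2)C(=O)CN(Cc2ccccc2C(F)(F)F)S(=O)(=O)c2ccc(F)c(F)c2)cc1` — 188 nM
Compound 2 `CC(C)(C)c1ccc(CN(C(=O)CN(Cc2ccccc2C(F)(F)F)S(=O)(=O)c2ccc(F)c(F)c2)c2ccc(C(=O)NO)cc2)cc1` — 362 nM
Compound 3 `O=C(NO)c1ccc(N(Cc2ccc(C(F)(F)F)cc2)C(=O)CN(Cc2ccccc2C(F)(F)F)S(=O)(=O)c2ccc(F)cc2F)cc1` — 151 nM

In an assay on Sf9 cells for inhibition of protein deacetylase HDAC6 (Homo sapiens), read by mobility shift assay (on this read-out lower numbers stand for stronger inhibition and higher numbers for weaker inhibition), compound 3 gives 151 nM, the lowest of the three numbers, although only its gap to compound 2 is beyond the scatter; compound 1 sits within the scatter of compound 3. Compound 4 `CC(C)(C)c1ccc(CN(C(=O)CN(Cc2ccccc2C(F)(F)F)S(=O)(=O)c2ccc(F)cc2F)c2ccc(C(=O)NO)cc2)cc1` differs from compound 3 by tert-butyl in place of trifluoromethyl on an aromatic carbon. Among the compounds with values here, one measured step bears on this change, the same exchange on the shared core: a 1.9-fold higher number from compound 1 to compound 2 (0.28 log units; within the scatter), which stayed within the scatter. A similar small shift toward a higher number is therefore expected here: a 1.9-fold higher number from compound 3 to compound 4 (0.28 log units; within the scatter). Compound 4 is accordingly estimated at 290 nM in this assay, with a range from 150 nM to 560 nM.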

Compound 4, half-maximal inhibitory concentration: 289 nM
Estimate against measurement, compound 4: 1.0-fold (0.00 log units) above, within the range that was stated.
By their numbers in this assay, from the lowest: compounds 3, 1, 4 and 2 (each within the scatter of the next, the first and the last beyond it).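

On a second core, the exchange of trifluoromethyl for tert-buryl gives a 1.9-fold higher number from compound 3 to compound 4 (0.28 log units; within the scatter), so the small shift seen earlier is not confined to one sulfonyl group: the same change on two cores in this assay, a 1.9-fold higher number (0.28 log units; within the scatter) from compound 1 to compound 2 and a 1.9-fold higher number (0.28 log units; within the scatter) from compound 3 to compound 4, 1.0-fold (0.00 log units) apart, within the scatter of two such steps. The fluorine pattern on the sulfonyl phenyl likewise gives a 1.3-fold lower number from compound 2 to compound 4 (0.10 log units; within the scatter) with tert-butyl in place, so in these four compounds each change reads the same whichever group sits at the other place: the same change on two cores in this assay, a 1.2-fold lower number (0.10 log units; within the scatter) from compound 1 to compound 3 and a 1.3-fold lower number (0.10 log units; within the scatter) from compound 2 to compound 4, 1.0-fold (0.00 log units) apart, within the scatter of two such steps. The compounds shown leave open whether a carboxylic acid or an amine on this aromatic carbon would move the number beyond the scatter. They also leave open what an unfluorinated phenyl on the sulfonyl sulfur would give.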